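Sulfonyl chain variation and liver microsome stability

The source may report more compounds than this note shows. Statements on the series, on what has been measured and on what is new or still open speak of the compounds shown alone.

Measured compounds:
compound 1 `CCS(=O)(=O)NC(=O)c1ccc(Nc2nc(NC3(c4ccc(Cl)cc4)CC3)nc(OCC(F)(F)F)n2)cc1` — 85%
compound 2 `CS(=O)(=O)NC(=O)c1ccc(Nc2nc(NC3(c4ccc(Cl)cc4)CC3)nc(OCC(F)(F)F)n2)cc1` — 85%

In an ADME assay on microsomes from liver (Rattus norvegicus) for metabolic stability, with a stated time of 10 min (on this read-out lower numbers stand for a less stable compound and higher numbers for a more stable compound), compound 1 gives 85%; compound 2 gives 85%. The single recorded step, no change at the digits printed from compound 1 to compound 2 (within the scatter), lies within the scatter, so compound 2 stands level with compound 1 on the numbers shown, and its nearest neighbour is compound 1 with no change beyond the scatter.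

Compound 3 `NCCS(=O)(=O)NC(=O)c1ccc(Nc2nc(NC3(c4ccc(Cl)cc4)CC3)nc(OCC(F)(F)F)n2)cc1` is the next variation at the same position: aminomethyl in place of hydrogen on a saturated chain carbon bound to a sulfonyl sulfur. For the measured compounds named here, the only measured step that bears on this is no change at the digits printed from compound 1 to compound 2 (within the scatter), which altered the substituent on the saturated chain carbon bound to the sulfonyl sulfur and showed no change in this assay. That step removed a methyl; the present one adds an aminomethyl, so the direction of change is not the same and an effect beyond the scatter cannot be ruled out, but nothing measured points to one. The expected step of a number 5 percentage points lower from compound 2 to compound 3 (within the scatter) is therefore within the scatter, leaning slightly lower given the wider range allowed. Compound 3 is estimated at 80%, with a range from 62% to 93%.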

Compound 3, percent of the compound remaining: 100%
The estimate for compound 3 lay 20 percentage points below the measured number; measured number above the stated range.
By their numbers in this assay, from the lowest: compounds 1 and 2 (each within the scatter of the next); then compound 3.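

In this assay, this position responds to a change after all: aminomethyl in place of hydrogen on a saturated chain carbon bound to a sulfonyl sulfur gives a number 15 percentage points higher from compound 2 to compound 3 (beyond the scatter), whereas removing the methyl had left the read-out within the scatter. The comparison with the ethyl compound points the same way, as amino in place of hydrogen on a saturated chain carbon, two bonds along the chain from a sulfonyl sulfur, gives a number 15 percentage points higher from compound 1 to compound 3 (beyond the scatter). Across these three compounds, the only one that stands apart carries the amino group, so the chain tolerates this substituent with no loss on this read-out, but no measurement in hand accounts for the shift.

As far as these compounds go, it remains open whether the shift belongs to the amine itself or would also appear with a hydroxyl, a carboxylic acid or a dimethylamino group at the same chain end. The compounds shown also leave open whether a longer chain carrying the amine, or an amine held in a ring on the sulfonyl group, would behave like compound 3.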